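Formyloxy to (Ethylcarbamoyl)oxy: Expecting Compound 3

The source may report more compounds than this note shows. Statements on the series, on what has been measured and on what is new or still open speak of the compounds shown alone.

Compound 1 `O=COCC1=CS(=O)(=O)c2ccccc2C1=O`: 91.6%
Compound 2 `O=C(OCC1=CS(=O)(=O)c2ccccc2C1=O)c1ccccc1`: 0%
Compound 3 `CCNC(=O)OCC1=CS(=O)(=O)c2ccccc2C1=O`: not yet measured

Of the compounds shown here, two of the shared core have been measured in a functional assay on the whole organism for inhibition, with Mus musculus as the target, at a dose of 10 mg/kg; on this read-out higher numbers stand for more inhibition at the one dose given (going by the name of the read-out) and lower numbers for less inhibition. Compound 1 gives 91.6%, the higher of the two numbers, while compound 2 gives 0%. Among the measured compounds shown here, the one measured step, a number 91.6 percentage points lower from compound 1 to compound 2 (beyond the scatter), bears directly on the carbonyl carbon that is altered again in compound 3.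

Compound 3 differs from compound 1 by ethylamino in place of hydrogen on a carbonyl carbon. For the measured compounds named here, the only measured change at this carbon is the one from compound 1 to compound 2, and it was large and downward. Going by the values given here, the ethylamino group is not the phenyl group, so the step cannot be read off that change alone, but it gives the only guide to how sensitive this read-out is to substitution on the carbonyl carbon. Compound 3 is therefore expected to fall below compound 1, with a wide range, a step of a number 51.6 percentage points lower from compound 1 to compound 3 (beyond the scatter). The estimated value for compound 3 is 40%, with a range from 0% to 90%.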

Compound 3, a percentage reported as inhibition, in the whole organism at one dose (the size of the read-out at that dose, not a potency): 99.3%
Beside the measured number, compound 3's estimate is 59.3 percentage points below it; the measured number lies above the stated range.
By their numbers in this assay, from the lowest: compound 2; then compounds 1 and 3 (each within the scatter of the next).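

In this assay, the step with ethylamino in place of hydrogen on the carbonyl carbon is a number 7.7 percentage points higher from compound 1 to compound 3 (within the scatter), so this carbon can carry a substituent and the read-out stays where it was with hydrogen, something the pair of compound 1 and compound 2 could not show. The outcome depends on which group enters, since ethylamino in place of phenyl on the same carbon gives a number 99.3 percentage points higher from compound 2 to compound 3 (beyond the scatter), and the collapse seen with phenyl therefore does not extend to every replacement of hydrogen here. Nothing given here explains why ethylamino and phenyl part so sharply at this carbon.

From the compounds shown here alone, with only hydrogen, ethylamino and phenyl on this carbon, it remains open whether methylamino, dimethylamino or a longer alkylamino chain such as butylamino would stay with compound 3 or fall towards compound 2, and whether anilino or benzylamino would bring the phenyl result back. Going by these compounds, because this assay reports a single dose and not a potency, it also remains open whether compound 1 and compound 3 would stay together at lower doses.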